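A few compounds are considered here, and "the series" means these few. Any claim that something is new, unique, unknown or untested is made for them only; others in the source may bear on it.

For the measured compounds named here, the two compounds measured so far share a core in which compound 1 `CCOC(=O)c1c(N)sc(-c2ccc(F)cc2)c1C` and compound 2 `CCOC(=O)c1c(N=C=S)sc(-c2ccccc2)c1C` differ at two places, so no single step can be drawn between them. In an in vitro functional assay on HEK293 cells for antagonist activity at metabotropic glutamate receptor 6 (Homo sapiens), read by reporter gene assay, luminescence and calcium flux, tested at 10 uM (a higher number here means a weaker inhibitor, a lower number a stronger inhibitor), compound 1 gives 12000 nM, while compound 2 gives 3500 nM. Going by the values given here, compound 2 thus stands lowest of the two numbers, with compound 1 the only neighbour, a gap that lies beyond the usual scatter.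

Compound 3 `CCOC(=O)c1c(Cl)sc(-c2ccccc2)c1C` is the next compound to be examined. Relative to compound 2 the change is one chlorine atom in place of a group of 3 heavy atoms (1 carbon, 1 nitrogen, 1 sulfur; no ring), on an aromatic carbon. Among the compounds with values here, no step of this kind has been measured here, so the size is uncertain. Within the data shown here, compound 3 is expected to give a somewhat higher number in this assay than compound 2, a step of a 2.3-fold higher number from compound 2 to compound 3 (0.36 log units; beyond the scatter), since the only known neighbour of compound 2, compound 1, sits at 12000 nM. The estimate for compound 3 is 8000 nM, with a range from 2500 nM to 25000 nM.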

Compound 3, half-maximal inhibitory concentration: 10000 nM
The estimate for compound 3 lay 1.3-fold (0.10 log units) below the measured number; low and high end bracket the measured number.
By their numbers in this assay, from the lowest: compound 2; then compounds 3 and 1 (each within the scatter of the next).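

In this assay, for the compounds shown here, the result gives the first reading of a change at a single place, the aromatic carbon next to the ring sulfur: chloro in place of the group of 3 heavy atoms (1 carbon, 1 nitrogen, 1 sulfur) gives a 2.9-fold higher number from compound 2 to compound 3 (0.46 log units; beyond the scatter), a modest step beyond the scatter. It shows that the number responds to what this carbon carries, with the larger group giving the lower number in this one pair. The compounds shown offer no measurement that accounts for this step.

Going by these compounds, it remains open how an amine at this carbon would compare with a phenyl group left unchanged, as compound 1 differs from compound 2 in a second place as well. On these data alone, whether a thiourea, an amide or a bromine atom here would lower the number further also stays unknown.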